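Pyridin-4-yl in Place of Phenyl at Two Positions

The source may report more compounds than this note shows. Statements on the series, on what has been measured and on what is new or still open speak of the compounds shown alone.

Compound 1 `O=S(=O)(c1ccccc1)n1ccc2c(-c3ccccc3)cccc21`: 162 nM
Compound 2 `O=S(=O)(c1ccccc1)n1ccc2c(-c3ccncc3)cccc21`: 1510 nM
Compound 3 `O=S(=O)(c1ccccc1)n1ccc2ccc(-c3ccccc3)cc21`: 178 nM

These values come from an assay on isolated protein for displacement of a labelled ligand from 5-hydroxytryptamine receptor 6 (Homo sapiens), read by scintillation counting, with a stated time of 1 h; a lower number here means a stronger inhibitor, a higher number a weaker inhibitor. Compound 1 and compound 3 are built from the same atoms joined differently; the difference between the two cores is not broken down here. From compound 1 to compound 2 the change is pyridin-4-yl in place of phenyl on an aromatic carbon, and it made a 9.3-fold higher number from compound 1 to compound 2 (0.97 log units; beyond the scatter). Compound 4 `O=S(=O)(c1ccccc1)n1ccc2ccc(-c3ccncc3)cc21` is not yet measured; it differs from compound 3 by pyridin-4-yl in place of phenyl on an aromatic carbon. The place differs: in the first case the carbon is ortho to a fused ring and meta to a fused ring, in the second meta to a fused ring and para to a fused ring, so this is the same kind of change rather than the same change. Compound 3 in this assay gives 178 nM, and a step of similar size is expected. Compound 4 is therefore expected to give 1500 nM, a step of an 8.4-fold higher number from compound 3 to compound 4 (0.93 log units; beyond the scatter), with a range from 450 nM to 5000 nM.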

Compound 4, inhibition constant: 38 nM
For compound 4 the middle estimate is 39-fold (1.60 log units) above the measured one, outside the stated range (below it).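

In this assay pyridin-4-yl in place of phenyl gave a 4.7-fold lower number from compound 3 to compound 4 (0.67 log units; beyond the scatter), the opposite direction to the step on the core of compound 1. The two results do not agree: the same change on two cores in this assay, a 9.3-fold higher number (0.97 log units; beyond the scatter) from compound 1 to compound 2 and a 4.7-fold lower number (0.67 log units; beyond the scatter) from compound 3 to compound 4, 44-fold (1.64 log units) apart, beyond the scatter of two such steps. Among the compounds shown here, this shows that the effect of this change on one core did not predict its effect on the other, but with only two pairs and a different place on each core, it does not show what sets them apart.

The compounds shown leave open how other groups at these places, such as an amine or a carboxylic acid, would behave. They also leave open whether pyridin-3-yl would follow pyridin-4-yl on either core.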